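A few compounds are considered here, and "the series" means these few. Any claim that something is new, unique, unknown or untested is made for them only; others in the source may bear on it.

Measured so far in a functional assay on DU-145 cells (Homo sapiens) for inhibition, read by trypan blue exclusion, with a stated time of 96 h; on this read-out higher numbers stand for weaker inhibition of growth and lower numbers for stronger inhibition of growth:
compound 1 `O=C(/C(=C\c1ccc(O)c([N+](=O)[O-])c1)S(=O)(=O)Cc1ccc(Br)cc1)c1c(F)c(F)c(F)c(F)c1F` gives 50000 nM
compound 2 `O=C(/C(=C\c1ccc(O)c([N+](=O)[O-])c1)SCc1ccc(Br)cc1)C1CCNC1` gives > 100000 nM
compound 3 `Cc1ccc(S/C(=C/c2ccc(N(C)C)cc2)C(=O)c2ccc(Cl)cc2)cc1` gives > 100000 nM

Compound 2 stands not at a number but at a limit of this assay, (the limit of > 100000 nM in this assay, at which 2 of the 3 values shown sit). Compound 3 likewise reaches only that limit. Among the measured compounds shown here, compound 1 is the single compound with a measured number, at 50000 nM.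

Compound 4 `O=C(/C(=C\c1ccc(O)c([N+](=O)[O-])c1)SCc1ccc(Br)cc1)c1ccc([N+](=O)[O-])cc1` keeps the core of compound 2 with one change: 4-nitrophenyl in place of pyrrolidin-3-yl on a carbonyl carbon. For the measured compounds named here, no step between two measured compounds is available, so the size of the change in this assay has no measured precedent. The expectation is a shift toward stronger growth inhibition, of a size beyond the scatter, with an at least 3.3-fold lower number from compound 2 to compound 4 (0.52 log units; beyond the scatter) as the estimated step. Compound 4 is accordingly expected at 30000 nM, in the range 8000 nM to 100000 nM.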

Compound 4, concentration for 50% growth inhibition: 10000 nM
Estimate against measurement, compound 4: 3.0-fold (0.48 log units) above; the range from low to high includes it.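

In this assay, the group on the carbonyl carbon proves to matter for growth inhibition: 4-nitrophenyl in place of pyrrolidin-3-yl gives an at least 10-fold lower number from compound 2 to compound 4 (1.00 log units; beyond the scatter). Among the compounds shown here, this is the first readable step. Its size is only a lower bound, as compound 2 gives a limit of the assay and not a number, > 100000 nM.

As far as these compounds go, whether the step comes from the aromatic ring or from its nitro group stays open; phenyl without a substituent or 4-aminophenyl on this carbonyl carbon would separate the two. Compound 1 and compound 3 differ from compound 4 in more than one place and do not settle this.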